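Vero cytotoxicity of compound 4 without the ring fluorine

The source may hold more compounds than are shown below. What is called first, only, known or untested is meant among the compounds shown, and "the series" means these compounds.

Measured in an ADME assay on Vero cells (Chlorocebus sabaeus) for cytotoxicity, read by MTT assay, with a stated time of 72 h; on this read-out lower numbers stand for higher toxicity in this test and higher numbers for lower toxicity in this test:
- compound 1 `CCOC(=O)c1c(-c2ccc(OC)cc2)oc2ccc(OCCCN3C(=O)C(=O)c4cc(F)ccc43)cc12`: 256000 nM
- compound 2 `CCOC(=O)c1c(-c2ccc(F)cc2)oc2ccc(OCCCN3C(=O)C(=O)c4cc(F)ccc43)cc12`: 512000 nM
- compound 3 `CCOC(=O)c1c(-c2ccc(OC)cc2)oc2ccc(OCCCCN3C(=O)C(=O)c4cc(OC)ccc43)cc12`: 64000 nM

Compound 1 holds the second highest of the three numbers in this assay. Its nearest neighbour is compound 2, and the step of a 2.0-fold higher number from compound 1 to compound 2 (0.30 log units; within the scatter) lies within the scatter. Compound 3 gives 64000 nM, a lower number, beyond the scatter from compound 1.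

Compound 4 `CCOC(=O)c1c(-c2ccc(OC)cc2)oc2ccc(OCCCN3C(=O)C(=O)c4ccccc43)cc12` differs from compound 1 by hydrogen in place of fluoro on an aromatic carbon. Going by the values given here, no measured pair makes this change; the only one-place step, a 2.0-fold higher number from compound 1 to compound 2 (0.30 log units; within the scatter), concerns a different group at a different ring and stayed within the scatter. Compound 4 is therefore expected to show no step beyond the scatter, no change at the digits printed from compound 1 to compound 4 (within the scatter). For compound 4 the estimate in this assay is 256000 nM, with a range from 100000 nM to 640000 nM.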

Compound 4, half-maximal cytotoxic concentration: 64000 nM
Beside the measured number, compound 4's estimate is 4.0-fold (0.60 log units) above it; the measured number lies below the stated range.
By their numbers in this assay, from the lowest: compounds 3 and 4 (each within the scatter of the next); then compounds 1 and 2 (each within the scatter of the next).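

In this assay, the ring fluorine on this six-membered aromatic ring matters: a 4.0-fold lower number from compound 1 to compound 4 (0.60 log units; beyond the scatter) lies beyond the scatter, whereas the change at the other ring, a 2.0-fold higher number from compound 1 to compound 2 (0.30 log units; within the scatter), stayed within it. Going by these compounds alone, this is the first single change to give a step beyond the scatter, and the higher number belongs to the fluorinated compound 1. Nothing available explains this step.

Still open, on these data alone, is whether chloro or a nitrile at this position would keep the number of compound 1. Also open, as far as these compounds go, is whether hydrogen in place of fluoro gives a similar step from compound 2.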